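The source may report more compounds than this note shows. Statements on the series, on what has been measured and on what is new or still open speak of the compounds shown alone.

Measured in a functional assay on QG-56 cells (Homo sapiens) for cytotoxicity, read by MTT assay, with a stated time of 48 h; a lower number here means a stronger inhibitor, a higher number a weaker inhibitor:
compound 1 `COc1cc(/C=C/C(=O)C2=C(/C=C/c3ccc(O)c(OC)c3)NC(=O)NC2c2ccccc2Cl)ccc1O`: 100000 nM
compound 2 `COc1cc(/C=C/C(=O)C2=C(/C=C/c3ccc(O)c(OC)c3)NC(=S)NC2c2ccccc2)ccc1O`: 100000 nM

Among the measured compounds shown here, compound 2 stands level with compound 1, within the scatter, and no measured pair yet differs in one place. Compound 3 `COc1cc(/C=C/C(=O)C2=C(/C=C/c3ccc(O)c(OC)c3)NC(=S)NC2c2ccc(C)cc2)ccc1O` differs from compound 2 by methyl in place of hydrogen on an aromatic carbon, para to a large group, turning phenyl to 4-methylphenyl. In this assay no step beyond the scatter is expected, an expectation resting only on compound 2 at 100000 nM. The estimated change is a 1.3-fold lower number from compound 2 to compound 3 (0.10 log units; within the scatter). Compound 3 is estimated at 80000 nM, with an expected range of 25000 nM to 150000 nM.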

Compound 3, half-maximal inhibitory concentration: 12500 nM
For compound 3 the middle estimate is 6.4-fold (0.81 log units) above the measured one; the whole stated range lies above it.
By their numbers in this assay, from the lowest: compound 3; then compounds 1 and 2 (each within the scatter of the next).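

In this assay, this position on the shared core responds to substitution: methyl in place of hydrogen on an aromatic carbon, para to a large group, gives an 8.0-fold lower number from compound 2 to compound 3 (0.90 log units; beyond the scatter) in a single-place change. Phenyl to 4-methylphenyl is therefore not a silent change in this thiocarbonyl series. No measured property bears on the origin of this step.

As far as these compounds go, whether ethyl, methoxy or chlorine at the same place would give a like step remains open. So does the effect of 4-methylphenyl with a carbonyl in place of the thiocarbonyl.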